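This account rests on a few compounds, and the source may have more. Where it says the series, first, only, none or still open, it means among the compounds named here.

Working notes on the series. For the measured compounds named here, compound 2 `CCCCNc1nc(N)c2nc(O)n(Cc3ccccc3)c2n1` holds the lowest of the two numbers so far in a functional assay on the whole organism for activation, with Mus musculus as the target (a higher number here means that more compound is needed for the effect, a lower number that less compound is needed), giving 0.1 mg/kg; compound 1 `Cc1nc(N)c2nc(O)n(Cc3ccccc3)c2n1` gives 3 mg/kg. Going by the values given here, the only measured step, a 30-fold lower number from compound 1 to compound 2 (1.48 log units; beyond the scatter), was large. Compound 3 `CCCc1nc(N)c2nc(O)n(Cc3ccccc3)c2n1` differs from compound 2 by propyl in place of butylamino on an aromatic carbon. That single step bears on the change: the butylamino group carried the whole gain over methyl, and propyl, with no hydrogen-bond donor or acceptor, is expected to give back part of it. For compound 3 a higher number is expected, estimated at 1 mg/kg, range 0.3 mg/kg to 3 mg/kg, a step of a 10-fold higher number from compound 2 to compound 3 (1.00 log units; beyond the scatter).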

Compound 3, minimum effective dose: 3 mg/kg
The estimate for compound 3 lay 3.0-fold (0.48 log units) below the measured number, and the stated range covers the measured number.
By their numbers in this assay, from the lowest: compound 2; then compounds 1 and 3 (each within the scatter of the next).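

In this assay, propyl in place of butylamino on this aromatic carbon gives a 30-fold higher number from compound 2 to compound 3 (1.48 log units; beyond the scatter), so the large gain does not survive this change. Extending methyl to propyl gives no change at the digits printed from compound 1 to compound 3 (within the scatter), so at this position a propyl chain alone does not reproduce the gain seen with butylamino. Nothing available explains the gap between these two groups. Still open, from the compounds shown here alone, is whether the linking nitrogen or the chain length carries the gain: butyl and propylamino at this position would separate the two.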